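The source may hold more compounds than are shown below. What is called first, only, known or untested is meant among the compounds shown, and "the series" means these compounds.

Compound 1 `Fc1ccc(CSc2nnc(-c3ccncc3)n2-c2ccccc2)cc1` and compound 2 `Fc1ccc(CSc2nnc(-c3ccncc3)n2-c2ccccc2)c(F)c1` differ in one place, a fluoro in place of hydrogen on an aromatic carbon. In a functional assay on HepG2 cells (Homo sapiens) for inhibition, read by MTT assay, with a stated time of 48 h (a lower number here means a stronger inhibitor, a higher number a weaker inhibitor), compound 1 gives 15600 nM and compound 2 gives 10200 nM. Going by the values given here, these two numbers cannot be told apart, so compound 2 stands level with compound 1 on the only evidence available. Compound 3 `Fc1cccc(F)c1CSc1nnc(-c2ccncc2)n1-c1ccccc1` has the same atoms as compound 2, joined differently: 2,6-difluorophenyl in place of 2,4-difluorophenyl on a saturated chain carbon bound to a sulfur. Put simply, 2,6-difluorophenyl stands in place of 2,4-difluorophenyl on a saturated chain carbon bound to a sulfur, which can also be read as 2,4-difluorobenzyl changing to 2,6-difluorobenzyl. Among the compounds with values here, the only measured step that bears on this change is a 1.5-fold lower number from compound 1 to compound 2 (0.18 log units; within the scatter). That step adds a fluoro rather than moving one, so it is only an indirect guide. With that single step to go on, no change beyond the scatter is expected in this assay, in either direction. The expected step is a 1.1-fold higher number from compound 2 to compound 3 (0.03 log units; within the scatter). For compound 3 the estimate is 11000 nM, with an expected range from 5000 nM to 25000 nM.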

Compound 3, half-maximal inhibitory concentration: > 50000 nM
Compound 3 ended at the assay's limit (the forecaster's own chance of this, stated with the estimate: 5%); middle value at least 4.5-fold (0.65 log units) away from the limit.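

In this assay, compound 3 sits at a limit of the assay rather than at a number: the limit of > 50000 nM in this assay, at which 1 of the 3 values shown sits.

Changing 2,4-difluorobenzyl to 2,6-difluorobenzyl, with the same atoms joined differently, brings an at least 4.9-fold higher number from compound 2 to compound 3 (0.69 log units; beyond the scatter), whereas the added fluoro of the earlier pair brought only a 1.5-fold lower number from compound 1 to compound 2 (0.18 log units; within the scatter). Measured against 4-fluorophenyl, the change points the same way, with an at least 3.2-fold higher number from compound 1 to compound 3 (0.50 log units; beyond the scatter), so among these three compounds the arrangement of the fluoros on this ring matters more than their number, although the full size of both new steps cannot be read past the limit.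

These compounds leave open whether the loss belongs to fluoro alone or to any group arranged as in 2,6-difluorophenyl, which chloro or methoxy in place of the fluoros would test. They also give no reason for the loss, and they do not show whether a longer chain in place of the saturated chain carbon bound to a sulfur would change the outcome.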